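The source may report more compounds than this note shows. Statements on the series, on what has been measured and on what is new or still open speak of the compounds shown alone.

Of the compounds shown here, two have so far been measured in a functional assay on PC-6 cells (Homo sapiens) for antiproliferative activity; on this read-out higher numbers stand for weaker inhibition and lower numbers for stronger inhibition. Compound 1 `CC(C)c1cc2c(N/N=C\c3ccccc3)ncnc2s1` gives 0.651 ug/mL in this assay. Compound 2 `Cc1cccc(/C=N\Nc2ncnc3sc(C(C)(C)C)cc23)n1` gives 0.258 ug/mL in this assay, the lowest of the two numbers; compound 1 sits a step above it that lies beyond the usual scatter. The next compound, compound 3 `CC(C)(C)c1cc2c(N/N=C\c3cccc(CO)n3)ncnc2s1`, has not yet been measured. The change from compound 2 to compound 3 is hydroxy in place of hydrogen on a saturated chain carbon bound to an aromatic carbon; the rest of the molecule stays the same. Going by the values given here, no measured pair shows this particular change, so its effect cannot be read from the numbers in hand. The step is expected to be small, with at most a slight move toward a higher number, around a 1.4-fold higher number from compound 2 to compound 3 (0.13 log units; within the scatter). Compound 3 is therefore estimated at 0.35 ug/mL in this assay, with a likely range from 0.12 ug/mL to 1 ug/mL.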

Compound 3, half-maximal inhibitory concentration: 0.034 ug/mL
Compound 3: middle estimate off by 10-fold (1.01 log units), on the high side, outside the stated range (below it).
By their numbers in this assay, from the lowest: compound 3; then compound 2; then compound 1.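

In this assay, the methyl of the 6-methylpyridin-2-yl group turns out not to be a silent spot: changing methyl to hydroxymethyl gives a 7.6-fold lower number from compound 2 to compound 3 (0.88 log units; beyond the scatter). Compounds 1 and 2 differ in more than one place, so they could not show what a single change does here, and this one adds only one oxygen atom on a saturated chain carbon bound to an aromatic carbon. Nothing at hand says what lies behind this step.

Going by these compounds, it remains open whether the hydroxy group itself matters or whether other groups at this place, such as an aminomethyl, a methoxymethyl or a carboxylic acid, would do the same. On these data alone, it is also open whether the step would hold on a different molecule, such as compound 1.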